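The source may report more compounds than this note shows. Statements on the series, on what has been measured and on what is new or still open speak of the compounds shown alone.

Measured in a functional assay on HCT-116 cells (Homo sapiens) for cytotoxicity, read by MTT assay, with a stated time of 72 h; a lower number here means a stronger inhibitor, a higher number a weaker inhibitor:
- compound 1 `CC1(C)OCC(Cn2cc(Cn3c4c(c5ccccc53)C(=O)c3c[n+]([O-])c5ccccc5c3C4=O)nn2)O1`: 70 nM
- compound 2 `CC1(C)O[C@@H](CO)[C@H](Cn2cc(Cn3c4c(c5ccccc53)C(=O)c3c[n+]([O-])c5ccccc5c3C4=O)nn2)O1`: 130 nM

The two values lie within the usual scatter of each other, so compound 2 cannot be separated from compound 1 on these numbers. The next compound is compound 3 `CC1(C)OC[C@H](Cn2cc(Cn3c4c(c5ccccc53)C(=O)c3c[n+]([O-])c5ccccc5c3C4=O)nn2)O1`, in which hydrogen takes the place of hydroxymethyl on a saturated ring carbon: hydrogen in place of hydroxymethyl on a saturated ring carbon. The same difference reads as 5-(hydroxymethyl)-2,2-dimethyl-1,3-dioxolan-4-yl going to 2,2-dimethyl-1,3-dioxolan-4-yl. Going by the values given here, one measured step bears on it, the same exchange in the opposite direction: a 1.9-fold higher number from compound 1 to compound 2 (0.27 log units; within the scatter). Among the compounds with values here, with only that small step as a guide, no change beyond the scatter is expected in this assay, and any drift should be towards a lower number. The expected step is a 1.6-fold lower number from compound 2 to compound 3 (0.21 log units; within the scatter). The estimate for compound 3 is 80 nM, with an expected range of 35 nM to 180 nM.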

Compound 3, half-maximal inhibitory concentration: 130 nM
Compound 3: the middle estimate sits 1.6-fold (0.21 log units) below what was measured; the measured number falls inside the stated range.
By their numbers in this assay, from the lowest: compounds 1, 2 and 3 (each within the scatter of the next).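

In this assay the exchange of hydroxymethyl for hydrogen on the saturated ring carbon gives no change at the digits printed from compound 2 to compound 3 (within the scatter), so at this position, in the pair with configurations drawn, the hydroxymethyl leaves no mark that can be separated from the scatter. The other new comparison gives a 1.9-fold higher number from compound 1 to compound 3 (0.27 log units; within the scatter), so the drawn S configuration at the ring carbon also cannot be told apart from the form drawn without one. That second comparison sets a defined form against an undefined one rather than two defined forms, since the only difference lies in how the stereocentre is drawn: the fact that one of compounds 1 and 3 is drawn with a defined configuration and the other without, at the place where they differ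

The compounds shown leave open whether the R configuration at this carbon would differ. They also leave open whether an amine, a carboxylic acid or a longer chain in place of the hydroxymethyl would move the number beyond the scatter.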